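A few compounds are considered here, and "the series" means these few. Any claim that something is new, unique, unknown or untested is made for them only; others in the source may bear on it.

Compound 1 `COc1cc(OC)c2cc(-c3ccc(OCc4ccccc4)cc3)c(O)nc2c1` is tested in a functional assay on MCF7 cells (Homo sapiens) for cytotoxicity, read by colorimetric assay and MTT assay (a lower number here means a stronger inhibitor, a higher number a weaker inhibitor), where compound 1 gives 10000 nM. Compound 2 `COc1ccc(-c2cc3c(OC)cc(OC)cc3n(CC(=O)OCc3ccccc3)c2=O)cc1` carries a different core; in this assay compound 2 gives 10000 nM. Compound 3 `COc1ccc(-c2cc3c(OC)cc(OC)cc3n(CC(=O)O)c2=O)cc1` in this assay gives 10000 nM. The difference between the two cores is not broken down here. From compound 2 to compound 3 the change is hydrogen in place of benzyl on an oxygen next to a carbonyl group, and it made no change at the digits printed from compound 2 to compound 3 (within the scatter). Compound 4 `COc1cc(OC)c2cc(-c3ccc(O)cc3)c(O)nc2c1` follows from compound 1 by hydrogen in place of benzyl on an oxygen on an aromatic ring. This is the same kind of change, not the same one: here it sits on an oxygen on an aromatic ring whose other neighbour is aromatic carbon, rather than on an oxygen next to a carbonyl group whose other neighbour is carbonyl carbon. Because no change at the digits printed from compound 2 to compound 3 (within the scatter) was flat, the step from compound 1 to compound 4 is expected to be about no change at the digits printed from compound 1 to compound 4 (within the scatter). Compound 4 is therefore estimated at 10000 nM, with a likely range from 3000 nM to 30000 nM.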

Compound 4, half-maximal inhibitory concentration: 10000 nM
Estimate against measurement, compound 4: no gap at the digits printed; the measured number falls inside the stated range.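

In this assay, hydrogen in place of benzyl on an oxygen on an aromatic ring made no change at the digits printed from compound 1 to compound 4 (within the scatter). Set beside the earlier step on the other core, the change carries across the two cores without a measurable difference: the same change on two cores in this assay, no change at the digits printed (within the scatter) from compound 2 to compound 3 and no change at the digits printed (within the scatter) from compound 1 to compound 4, 1.0-fold (0.00 log units) apart, within the scatter of two such steps. All four compounds stand at one printed value, so this shows agreement only at that level; it does not show how the change would carry over in a compound with a different value, or on a further core.

The compounds shown leave open whether any other group in place of benzyl would move the value. A longer chain, or a chain ending in an amine or a carboxylic acid, on that oxygen remains an open case.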